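Open-chain amine in place of a cyclic one

The compounds below may be only part of what the source reports. "The series", "measured", "known", "first", "only" and "open" are said of these compounds alone.

Compound 1 `O=c1c(SC(=S)N2CCCCC2)coc2ccccc12` gives 9000 nM in a functional assay on HeLa cells (Homo sapiens) for antiproliferative activity, read by MTT assay, with a stated time of 72 h; on this read-out lower numbers stand for stronger inhibition and higher numbers for weaker inhibition. Compound 2 `O=c1cc(CSC(=S)N2CCCC2)oc2ccccc12` gives 23100 nM in this assay; compounds 1 and 2 differ in several places at once, so their two values show only that both inhibit weakly. Compound 3 `O=c1cc(CSC(=S)N2CCCC2)oc2cc(Cl)ccc12` reaches only the limit of this assay, > 40000 nM, which is a limit and not a number. The step of an at least 1.7-fold higher number from compound 2 to compound 3 (0.23 log units; that floor lies within the scatter) is therefore at least as large as that floor. Compound 3 thus stands at the weak end of the compounds shown, as the line the limit of > 40000 nM in this assay, at which 1 of the 3 values shown sits, records.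

Compound 4 `CCN(CC)C(=S)SCc1cc(=O)c2ccc(Cl)cc2o1` differs from compound 3 by diethylamino in place of pyrrolidin-1-yl on a thiocarbonyl carbon. No measured step changes the amine on the thiocarbonyl carbon, so nothing shown bears directly on this change; the single measured step of an at least 1.7-fold higher number from compound 2 to compound 3 (0.23 log units; that floor lies within the scatter) concerns the aromatic ring instead. Among the compounds with values here, with compound 3 at the limit and no step pointing to a gain, compound 4 is expected to stay near that limit, the step that the limit leaves unreadable from compound 3 to compound 4 being expected to lie within the scatter. The estimate for compound 4 is 45000 nM, expected between 15000 nM and 150000 nM.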

Compound 4, half-maximal inhibitory concentration: 8700 nM
For compound 4 the middle estimate is 5.2-fold (0.71 log units) above the measured one; the whole stated range lies above it.
By their numbers in this assay, from the lowest: compounds 4 and 1 (each within the scatter of the next); then compound 2. At a limit, above all of these: compound 3.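

On the thiocarbonyl carbon the amine makes a measurable difference: with the rest of the molecule unchanged, diethylamino in place of pyrrolidin-1-yl gives an at least 4.5-fold lower number from compound 3 to compound 4 (0.66 log units; beyond the scatter) in this assay. The two groups hold the same count of heavy atoms and differ in that one has a ring and the other has none, and this is the only step shown that leads to a lower number. The true size of the step remains unknown, as only its floor can be read: the limit of > 40000 nM in this assay, at which 1 of the 4 values shown sits.

From the compounds shown here alone, whether diethylamino would give a similar step without the chloro group, on the core of compound 2, remains open. Also open, going by these compounds, is how dimethylamino, dipropylamino or morpholin-4-yl would read on the same thiocarbonyl carbon.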